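The compounds below may be only part of what the source reports. "The series", "measured", "known", "first", "only" and "open" are said of these compounds alone.

Measured so far in an assay on cells for inhibition of Voltage-dependent T-type calcium channel subunit alpha-1H (Homo sapiens), read by FLIPR and calcium flux, with stated times of 600 s and 300 s; a higher number here means a weaker inhibitor, a lower number a stronger inhibitor:
compound 1 `CN(C)CCCOc1ccc(CN(C)c2nc3ccc(Oc4ccc(C(F)(F)F)cc4)cc3s2)cc1`, 54000 nM
compound 2 `CN(Cc1ccc(OCCCNC(=N)N)cc1)c1nc2ccc(Oc3ccc(C(F)(F)F)cc3)cc2s1`, 212000 nM
compound 3 `CN(Cc1ccc(OCCCN)cc1)c1nc2ccc(Oc3ccc(C(F)(F)F)cc3)cc2s1`, 248000 nM

Compound 2 gives the second highest of the three numbers in this assay; it lies within the scatter of compound 3 and clearly apart from compound 1, as a 3.9-fold higher number from compound 1 to compound 2 (0.59 log units; beyond the scatter) and a 1.2-fold higher number from compound 2 to compound 3 (0.07 log units; within the scatter) show. Compound 4 `CN(Cc1ccc(OCCCNC(=N)N)cc1)c1nc2ccc(Oc3ccc(O)cc3)cc2s1` differs from compound 2 by hydroxy in place of trifluoromethyl on an aromatic carbon. For the measured compounds named here, none of the measured steps touches this part of the shared core: a 3.9-fold higher number from compound 1 to compound 2 (0.59 log units; beyond the scatter), a 4.6-fold higher number from compound 1 to compound 3 (0.66 log units; beyond the scatter) and a 1.2-fold higher number from compound 2 to compound 3 (0.07 log units; within the scatter) all concern the chain end and were modest or within scatter. The change thus has no anchor in the series, and any step in this assay is expected to be modest, direction uncertain, leaning toward a higher number. Compound 4 is accordingly estimated at 300000 nM, range 100000 nM to 900000 nM, meaning an expected 1.4-fold higher number from compound 2 to compound 4 (0.15 log units; within the scatter).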

Compound 4, half-maximal inhibitory concentration: 332000 nM
The estimate for compound 4 lay 1.1-fold (0.04 log units) below the measured number; low and high end bracket the measured number.
By their numbers in this assay, from the lowest: compound 1; then compounds 2, 3 and 4 (each within the scatter of the next).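

The 4-(trifluoromethyl)phenoxy group of compound 2 becomes 4-hydroxyphenoxy in compound 4, the first change away from the chain end, and in this assay the result is a 1.6-fold higher number from compound 2 to compound 4 (0.19 log units; within the scatter). Trifluoromethyl and hydroxy are therefore not told apart at this position when this chain end is present. No available measurement accounts for this result.

Open, from the compounds shown here alone, is whether the same exchange reads alike with the dimethylamino chain end of compound 1. Also open, going by these compounds, is how a chlorine, a methoxy or a carboxylic acid would read at this position.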